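Halogen pattern swap on the aniline of a quinazoline series

This account rests on a few compounds, and the source may have more. Where it says the series, first, only, none or still open, it means among the compounds named here.

Measured compounds:
compound 1 `COc1cc2ncnc(Nc3ccc(Cl)cc3)c2cc1OCCCCC(=O)Nc1ccc(S(N)(=O)=O)cc1` — 7120 nM
compound 2 `COc1ccc(Nc2ncnc3cc(OC)c(OCCCCC(=O)Nc4ccc(S(N)(=O)=O)cc4)cc23)cc1OC` — 35400 nM
compound 3 `COc1cc2ncnc(Nc3ccc(F)c(Br)c3)c2cc1OCCCCC(=O)Nc1ccc(S(N)(=O)=O)cc1` — 8020 nM

In a functional assay on A-431 cells (Homo sapiens) for antiproliferative activity, read by MTT assay, with a stated time of 72 h (on this read-out higher numbers stand for weaker inhibition and lower numbers for stronger inhibition), compound 3 stands second highest of the three numbers; it sits next to compound 1, with a 1.1-fold higher number from compound 1 to compound 3 (0.05 log units; within the scatter) within the scatter, while compound 2 lies furthest away, a 4.4-fold lower number from compound 2 to compound 3 (0.64 log units; beyond the scatter).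

Compound 4 `COc1cc2ncnc(Nc3cccc(Cl)c3F)c2cc1OCCCCC(=O)Nc1ccc(S(N)(=O)=O)cc1` differs from compound 3 by 3-chloro-2-fluorophenyl in place of 3-bromo-4-fluorophenyl on a nitrogen on an aromatic ring. Among the compounds with values here, the step that bears most on this change is the one from compound 1 to compound 3, where one halogenated phenyl replaced another and the number hardly moved. The larger step from compound 2 to compound 3 involved a dimethoxyphenyl and is less relevant here. Compound 4 is therefore expected to show no step beyond the scatter in this assay, a 1.0-fold lower number from compound 3 to compound 4 (0.00 log units; within the scatter). Compound 4 is estimated at 8000 nM, within a range of 3500 nM to 18000 nM.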

Compound 4, half-maximal inhibitory concentration: 5560 nM
For compound 4 the middle estimate is 1.4-fold (0.16 log units) above the measured one; measured number inside the range.
By their numbers in this assay, from the lowest: compounds 4, 1 and 3 (each within the scatter of the next); then compound 2.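

In this assay, a third halogen pattern on this nitrogen, 3-chloro-2-fluorophenyl, stays level with the other two halogenated phenyl groups (a 1.4-fold lower number from compound 3 to compound 4 (0.16 log units; within the scatter); a 1.3-fold lower number from compound 1 to compound 4 (0.11 log units; within the scatter)), so moving the halogens and exchanging bromine for chlorine shows no effect beyond the scatter among these compounds. Compound 2 remains the exception, and its gap is confirmed by a third halogenated partner (a 6.4-fold lower number from compound 2 to compound 4 (0.80 log units; beyond the scatter)). No measurement at hand explains this difference. The compounds shown leave open whether an amine or a carboxylic acid on this phenyl ring, or a longer chain on the shared core, would move the number beyond the scatter.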